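A few compounds are considered here, and "the series" means these few. Any claim that something is new, unique, unknown or untested is made for them only; others in the source may bear on it.

The shared core of compound 1 `Nc1nc(OCC(F)(F)F)c2ncn(/C=C3/CC3(CO)CO)c2n1` carries a 2,2,2-trifluoroethoxy group on an aromatic carbon. In an ADME assay on Akata cells (Homo sapiens) for cytotoxicity, with a stated time of 7 days (a higher number here means that more compound is tolerated, a lower number that less compound is tolerated), compound 1 gives > 20000 nM, which is a limit of the assay rather than a number. Compound 1 thus stands at the limit of > 20000 nM in this assay, at which 2 of the 3 values shown sit, and no measured value in this set rises above a limit. Compound 2 `CCOc1nc(N)nc2c1ncn2/C=C1/CC1(CO)CO`, with methyl in place of trifluoromethyl on a saturated chain carbon bound to an oxygen on an aromatic ring, gives > 20000 nM, again a limit. Compound 3 `CCCNc1nc(N)nc2c1ncn2/C=C1/CC1(CO)CO`, with propylamino in place of ethoxy on an aromatic carbon, gives > 24000 nM, also a limit, at the limit of > 24000 nM in this assay, at which 1 of the 3 values shown sits. The steps a step that the two limits leave unreadable from compound 1 to compound 2, a step that the two limits leave unreadable from compound 1 to compound 3 and a step that the two limits leave unreadable from compound 2 to compound 3 are therefore all unreadable in size.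

Compound 4 `CSc1nc(N)nc2c1ncn2/C=C1/CC1(CO)CO` differs from compound 1 by methylsulfanyl in place of 2,2,2-trifluoroethoxy on an aromatic carbon. Going by the values given here, none of the measured steps bears readably on this change, since every value sits at a limit; the only expectation the data support is that compound 4 is tolerated up to a similar limit, with no step beyond the scatter expected in this assay. The estimated step is a step that the limit leaves unreadable from compound 1 to compound 4. Compound 4 is therefore expected to give about 25000 nM, in the range from 10000 nM to 60000 nM.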

Compound 4, half-maximal cytotoxic concentration: > 20000 nM
Compound 4 ended at the assay's limit; the forecaster's own chance of this, stated with the estimate: 85%; the middle value lies beyond the limit too.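

In this assay compound 4 gives > 20000 nM as a limit and not a number. Its steps to compound 1, compound 2 and compound 3 therefore cannot be read in size. The compounds shown leave open at what concentration any of them harms these cells, and whether changing the group on this aromatic carbon alters that concentration.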